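Swapping a Sulfonamide for Hydroxymethyl: Expected Half-Life

The compounds below may be only part of what the source reports. "The series", "measured", "known", "first", "only" and "open" are said of these compounds alone.

Among the compounds with values here, compound 2 `CCCCN(c1nc2c(NS(C)(=O)=O)cccc2o1)[C@H](C)c1ccc(-c2ccccc2-c2nnn[nH]2)cc1` gives 4.7 h in an ADME assay on the whole organism (Macaca fascicularis) for metabolic stability, read by LC-MS, using cassette dosing, at a dose of 1 mg/kg by the oral route (a lower number here means that the compound disappears faster, a higher number that the compound lasts longer), the highest of the three numbers measured so far. Within the data shown here, compound 3 `CCCCN(c1nc2c(C(=O)O)cccc2o1)[C@H](C)c1ccc(-c2cc(Cl)ccc2-c2nc(=O)o[nH]2)cc1` gives 2 h and compound 1 `C[C@H](c1ccc(-c2cc(Cl)ccc2-c2nc(=O)o[nH]2)cc1)N(CC1CC1)c1nc2c(C(=O)O)cccc2o1` gives 0.8 h; the only single-point step among them, a 2.5-fold higher number from compound 1 to compound 3 (0.40 log units; beyond the scatter), concerns the chain on the nitrogen and not the aromatic position altered here. Compound 4 `CCCCN(c1nc2c(CO)cccc2o1)[C@H](C)c1ccc(-c2ccccc2-c2nnn[nH]2)cc1` differs from compound 2 by hydroxymethyl in place of methanesulfonamido on an aromatic carbon. Among the measured compounds shown here, no measured step bears on this change, so the expectation rests on compound 2 alone and remains uncertain. For compound 4 a modest decrease a 1.9-fold lower number from compound 2 to compound 4 (0.27 log units; within the scatter) is expected, with a half-life estimated at 2.5 h and a range from 0.9 h to 6 h.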

Compound 4, half-life: 1.6 h
Beside the measured number, compound 4's estimate is 1.6-fold (0.19 log units) above it; low and high end bracket the measured number.
By their numbers in this assay, from the lowest: compounds 1, 4 and 3 (each within the scatter of the next, the first and the last beyond it); then compound 2.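

In this assay, the half-life depends on what sits on this aromatic carbon: hydroxymethyl in place of methanesulfonamido gives a 2.9-fold lower number from compound 2 to compound 4 (0.47 log units; beyond the scatter). This is the first step shown at this position, as the earlier step concerned only the chain on the nitrogen. No available evidence explains the shorter half-life.

As far as these compounds go, how an amine or a methoxy group on this aromatic carbon would compare remains open. So does whether any group other than methanesulfonamido would match the half-life of compound 2.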